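The compounds below may be only part of what the source reports. "The series", "measured", "known", "first", "only" and "open" are said of these compounds alone.

Measured compounds:
compound 1 `C=C1C[C@]23C[C@@]1(O)CC[C@H]2c1cc(Br)c(O)c(C)c1[C@@H]3Cn1cc(-c2ccc(C)cc2)nn1` — > 20000 nM
compound 2 `C=C1C[C@]23C[C@@]1(O)CC[C@H]2c1ccc(OS(=O)(=O)c2ccc(C)cc2)c(C)c1[C@@H]3Cn1cc(-c2ccc(C)cc2)nn1` — > 20000 nM

In a functional assay on SW480 cells (Homo sapiens) for cytotoxicity, read by MTT assay, with a stated time of 4 days (a lower number here means a stronger inhibitor, a higher number a weaker inhibitor), compound 1 gives > 20000 nM, which is a limit of the assay and not a number. Compound 2 likewise gives > 20000 nM in this assay, again only a limit. What the data show is the limit of > 20000 nM in this assay, at which 2 of the 2 values shown sit. Compound 3 `C=C1C[C@]23C[C@@]1(O)CC[C@H]2c1cc(Br)c(O)c(C)c1[C@@H]3Cn1cc(-c2ccc(Cl)cc2)nn1` differs from compound 1 by chloro in place of methyl on an aromatic carbon. Within the data shown here, no measured step between compounds is available, so compound 1 stands only at its limit. The expectation is no change beyond the scatter, a step that the limit leaves unreadable from compound 1 to compound 3. Compound 3 is thus estimated at 25000 nM, within 8000 nM to 80000 nM, most probably reported again as a limit.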

Compound 3, half-maximal inhibitory concentration: 18000 nM
For compound 3 the middle estimate is 1.4-fold (0.14 log units) above the measured one; the measured number falls inside the stated range.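

In this assay, among these compounds, compound 3 gives 18000 nM, the only value here that is a number and not a limit. Chloro in place of methyl, para to a large group, gives an at least 1.1-fold lower number from compound 1 to compound 3 (0.04 log units; that floor lies within the scatter), so the true size of this step cannot be read and no gain can be claimed. Most of the series still rests at the limit: the limit of > 20000 nM in this assay, at which 2 of the 3 values shown sit.

As far as these compounds go, whether an amine, a methoxy or a carboxylic acid at this place would move the value clearly remains open. So does whether any change elsewhere on the shared core would do so.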